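The source may hold more compounds than are shown below. What is called first, only, known or untested is meant among the compounds shown, and "the series" means these compounds.

In a functional assay on HL-60 cells (Homo sapiens) for inhibition, read by resazurin assay, with a stated time of 72 h (a higher number here means a weaker inhibitor, a lower number a stronger inhibitor), compound 1 `CCSc1ccc(C2C(O)C(=O)N2c2cc(OC)c(OC)c(OC)c2)cc1` gives 16 nM and compound 2 `C=CC1C(=O)N(c2cc(OC)c(OC)c(OC)c2)C1c1ccc(SCC)cc1` gives 320 nM, so compound 2 holds the higher number of the two and is the weaker inhibitor. Compound 3 `CCSc1ccc(C2C(C3CC3)C(=O)N2c2cc(OC)c(OC)c(OC)c2)cc1` carries cyclopropyl in place of vinyl on a saturated ring carbon. Among the compounds with values here, only one measured step bears on this change: a 20-fold higher number from compound 1 to compound 2 (1.30 log units; beyond the scatter), a large step with vinyl in place of hydroxy on that same saturated ring carbon. It shows that the number can move widely with the group at this carbon, but it replaces hydroxy, not one carbon group with another. Within the data shown here, no measured pair compares vinyl with cyclopropyl, so no direction is favoured and no step beyond the scatter is expected. The expected change is a 1.1-fold lower number from compound 2 to compound 3 (0.03 log units; within the scatter). For compound 3 the estimated value in this assay is 300 nM, with an expected range of 100 nM to 1000 nM.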

Compound 3, half-maximal inhibitory concentration: 803 nM
Compound 3: middle estimate off by 2.7-fold (0.43 log units), on the low side; the measured number falls inside the stated range.
By their numbers in this assay, from the lowest: compound 1; then compound 2; then compound 3.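

This position separates the two carbon groups as well as hydroxy from carbon: in this assay there is a 2.5-fold higher number from compound 2 to compound 3 (0.40 log units; beyond the scatter), so the number at this saturated ring carbon depends on which carbon group sits there, not only on the loss of hydroxy. Hydroxy keeps the lowest number of the three, with a 50-fold higher number from compound 1 to compound 3 (1.70 log units; beyond the scatter), and neither vinyl nor cyclopropyl comes close to it. Nothing available explains why the number moves with these groups.

On these data alone, whether the low number of compound 1 is particular to hydroxy, or would also hold for an amine or a methoxy group on this carbon, remains open. As far as these compounds go, it is also open whether a saturated chain such as ethyl, or a longer chain, would follow the rise seen with cyclopropyl.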